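The source may hold more compounds than are shown below. What is called first, only, known or untested is meant among the compounds shown, and "the series" means these compounds.

In a functional assay on EL4 cells (Mus musculus) for inhibition, tested at 100 uM (a lower number here means less inhibition, a higher number more inhibition at the concentration tested (going by the name of the read-out)), compound 2 `CNc1nccc2c1ncn2C1O[C@H](CO)[C@@H](O)[C@H]1O` gives 11%. Among the two numbers shown it stands highest; the nearest is compound 1 `CN(C)c1nccc2c1ncn2C1O[C@H](CO)[C@@H](O)[C@H]1O`, which in this assay gives 10%, a gap within the scatter. Among the measured compounds shown here, the step of a number 1 percentage points higher from compound 1 to compound 2 (within the scatter) is the only measured step in which a single place changes, and it moves nothing beyond the scatter. Compound 3 `OC[C@H]1O[C@@H](n2cnc3c(S)nccc32)C[C@@H]1O` is reported in this assay only as a limit, < 5%; that is the limit of < 5% in this assay, at which 1 of the 3 values shown sits.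

Compound 4 `OC[C@H]1OC(n2cnc3c(Cl)nccc32)[C@H](O)[C@@H]1O` differs from compound 2 by chloro in place of methylamino on an aromatic carbon. For the measured compounds named here, no measured step covers a change at that carbon; the step from compound 1 to compound 2 concerns only the substituent on the nitrogen and stayed within the scatter, so it offers no direction for the exchange of the whole methylamino group. Every number in the series sits low and one value sits at the limit. For compound 4 the expected change is therefore a number 3 percentage points lower from compound 2 to compound 4 (within the scatter), nothing beyond the scatter. Compound 4 is estimated at 8%, between 2% and 18%, with a fair chance that only the limit is reported.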

Compound 4, a percentage reported as inhibition, at one concentration (the size of the read-out at that concentration, not a potency): < 5%
Compound 4: a limit, no number; the forecaster's own chance of this, stated with the estimate: 30%; middle value at least 3 percentage points from the limit.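

In this assay compound 4 gives < 5%, which is a limit and not a number. Chloro in place of methylamino on this aromatic carbon gives a number at least 6 percentage points lower from compound 2 to compound 4 (that floor lies within the scatter), and chloro in place of dimethylamino gives a number at least 5 percentage points lower from compound 1 to compound 4 (that floor lies within the scatter); these are the first readings of an exchange of the whole substituent at this position, and neither floor clears the scatter. With chloro at this position, the series gains a further value at the limit: the limit of < 5% in this assay, at which 2 of the 4 values shown sit.

The true size of both steps stays open, and the compounds shown give no firm direction for this aromatic carbon. Also open, from the compounds shown here alone, is how a primary amine, a methoxy group or a longer alkylamino chain at this position would read, and whether any substituent there raises inhibition beyond the scatter.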